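Changing the amide substituent in a thiazolopiperidine series

The compounds below may be only part of what the source reports. "The series", "measured", "known", "first", "only" and "open" are said of these compounds alone.

Measured so far:
- compound 1 `O=C(C1CCC1)N1CCc2nc(C#Cc3ccccc3)sc2C1`: > 10000 nM
- compound 2 `O=C(C1CCCO1)N1CCc2nc(C#Cc3ccccc3)sc2C1`: 790 nM

Of the compounds shown here, two sharing one core have been measured in an assay on HEK293 cells for positive allosteric modulation of metabotropic glutamate receptor 5 (Homo sapiens), read by FLIPR, with a stated time of 1 h; on this read-out higher numbers stand for an effect only at larger amounts of compound and lower numbers for an effect already at smaller amounts. For compound 1 the result is a limit of the assay, > 10000 nM, and not a number; this is the limit of > 10000 nM in this assay, at which 1 of the 2 values shown sits. Among the measured compounds shown here, compound 2 gives 790 nM, which makes it the only compound with a number in this assay. For the measured compounds named here, the one measured step, an at least 12-fold lower number from compound 1 to compound 2 (1.10 log units; beyond the scatter), turns a limit into a number on replacing cyclobutyl with oxolan-2-yl at the carbonyl carbon.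

Compound 3 `Cc1cccc(C(=O)N2CCc3nc(C#Cc4ccccc4)sc3C2)n1` has not yet been measured. It differs from compound 2 in 6-methylpyridin-2-yl in place of oxolan-2-yl on a carbonyl carbon. Going by the values given here, no measured step changes the same position in the same way, so the step from the cyclobutyl to the oxolan-2-yl amide is the only guide, and it concerns a different pair of groups. The author therefore expects a step of a 2.0-fold lower number from compound 2 to compound 3 (0.30 log units; within the scatter) for compound 3, with wide uncertainty. For compound 3 the estimated value in this assay is 400 nM, with a range from 60 nM to 3000 nM.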

Compound 3, half-maximal effective concentration: 160 nM
Compound 3: the middle estimate sits 2.5-fold (0.40 log units) above what was measured; the measured number falls inside the stated range.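

In this assay the substituent on the carbonyl carbon need not be a non-aromatic ring, and the aromatic 6-methylpyridin-2-yl goes beyond what oxolan-2-yl gave, with a 4.9-fold lower number from compound 2 to compound 3 (0.69 log units; beyond the scatter). Measured against cyclobutyl, the same group gives an at least 62-fold lower number from compound 1 to compound 3 (1.79 log units; beyond the scatter), so among these three compounds both groups with a hetero atom in the ring give a number, and no compound goes against this. Compound 1, which carries cyclobutyl and has no hetero atom in that ring, remains the only one of the three with a limit of the assay and not a number: the limit of > 10000 nM in this assay, at which 1 of the 3 values shown sits.

The single step from oxolan-2-yl to 6-methylpyridin-2-yl changes ring size, aromatic character, the hetero atom and the methyl group all at once, so the compounds shown do not tell which of these changes goes with the lower number. From the compounds shown here alone, it remains open how a plain phenyl ring, a pyridin-2-yl ring without the methyl group, or an open chain such as methoxyethyl would read at this position, and the values give no reason for either step.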